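The compounds below may be only part of what the source reports. "The series", "measured", "known", "first", "only" and "open" are said of these compounds alone.

Among the measured compounds shown here, in a physicochemical assay for lipophilicity, at pH 7.4 (on this read-out higher numbers stand for higher lipophilicity and lower numbers for lower lipophilicity), compound 2 (`O=C(O)Cc1nn(Cc2cn3cc(OCC4CC4)c(Cl)cc3n2)c2ccccc2c1=O`) gives 2.13, the second highest of three numbers so far. Compound 1 (`O=C(O)Cn1nc(Cc2nc3cc(Cl)c(OC(F)(F)F)cc3[nH]2)c2ccccc2c1=O`) stands clearly higher at 2.54, and compound 3 (`COc1ccc(NC(=O)Cc2nn(CC(=O)O)c(=O)c3ccccc23)c(OC)c1`) clearly lower at 1.13. Compound 4 (`O=C(O)C1(c2nn(Cc3cn4cc(OCC5CC5)c(Cl)cc4n3)c3ccccc3c2=O)CC1`) has not yet been measured. It carries one change from compound 2: 1-carboxycyclopropyl in place of carboxymethyl on an aromatic carbon. For the measured compounds named here, no two measured compounds differ in one place only, so the data offer no direct guide to this step. The entering group adds carbon but no further oxygen, and a small rise is expected, about the size of the usual scatter. The expected change is a number 0.27 log units higher from compound 2 to compound 4 (within the scatter). For compound 4 the estimated value is 2.4, with an expected range from 2 to 2.8.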

Compound 4, distribution coefficient: 2.46
Estimate against measurement, compound 4: 0.06 log units below, within the range that was stated.
By their numbers in this assay, from the lowest: compound 3; then compound 2; then compounds 4 and 1 (each within the scatter of the next).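

In this assay, putting 1-carboxycyclopropyl in place of carboxymethyl on this aromatic carbon gives a number 0.33 log units higher from compound 2 to compound 4 (beyond the scatter) as a modest step. This is the only comparison shown that isolates a single change, so it shows that this position, next to the ring nitrogen, responds measurably to this swap on the core of compound 2. Nothing measured here explains the rise. Still open, on these data alone, is whether 1-carboxycyclobutyl or a tetrazole in place of the carboxylic acid would move the number further, and whether the same swap would give a similar step on the core of compound 1.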